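Bromo and methylphenyl on a shared core, cytotoxicity

The source may report more compounds than this note shows. Statements on the series, on what has been measured and on what is new or still open speak of the compounds shown alone.

Compound 2 `C=C1C[C@]23C[C@@]1(O)CC[C@H]2c1ccc(O)c(C)c1[C@@H]3Cn1cc(-c2ccc(F)cc2)nn1` carries a hydrogen where compound 1 `C=C1C[C@]23C[C@@]1(O)CC[C@H]2c1cc(Br)c(O)c(C)c1[C@@H]3Cn1cc(-c2ccc(F)cc2)nn1` carries bromo, the difference being (bromo in place of hydrogen on an aromatic carbon). In a functional assay on SW480 cells (Homo sapiens) for cytotoxicity, read by MTT assay, with a stated time of 4 days (on this read-out lower numbers stand for stronger inhibition and higher numbers for weaker inhibition), compound 2 reports only a limit, > 20000 nM. Compound 1 likewise reports only a limit in this assay, > 20000 nM. The step that the two limits leave unreadable from compound 2 to compound 1 therefore has no readable size. Compound 3 `C=C1C[C@]23C[C@@]1(O)CC[C@H]2c1ccc(O)c(C)c1[C@@H]3Cn1cc(-c2ccc(C)cc2)nn1` differs from compound 2 by methyl in place of fluoro on an aromatic carbon; in this assay compound 3 gives only a limit, > 20000 nM. The step that the two limits leave unreadable from compound 2 to compound 3 is equally unreadable. Compound 4 `C=C1C[C@]23C[C@@]1(O)CC[C@H]2c1cc(Br)c(O)c(C)c1[C@@H]3Cn1cc(-c2ccc(C)cc2)nn1`, not yet measured, differs from compound 3 by bromo in place of hydrogen on an aromatic carbon, the same change as that from compound 2 to compound 1. For compound 4 the step that the limit leaves unreadable from compound 3 to compound 4 is expected to stay unreadable because every measured value sits at the limit of > 20000 nM in this assay, at which 3 of the 3 values shown sit. Compound 4 is estimated at 30000 nM, between 15000 nM and 100000 nM.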

Compound 4, half-maximal inhibitory concentration: > 20000 nM
Compound 4: only a limit was reported; the forecaster's own chance of this, stated with the estimate: 85%; the middle value lies beyond the limit too.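

Compound 4 gives only a limit, as do compound 1 and compound 3, so neither step into compound 4 can be read: the limit of > 20000 nM in this assay, at which 4 of the 4 values shown sit. The compounds shown leave open whether bromo in place of hydrogen, or methyl in place of fluoro, changes potency in this assay at all.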